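Series notes: trimethoxyphenyl variant of compound 3

The source may hold more compounds than are shown below. What is called first, only, known or untested is meant among the compounds shown, and "the series" means these compounds.

Three compounds share one core and differ only in the aryl group next to the ring oxygen: compound 1 `O=c1cc(-c2cccc(O)c2)oc2cc(OCCCCCCCCN3CCCC3)ccc12`, compound 2 `O=c1cc(-c2ccc(-c3ccccc3)cc2)oc2cc(OCCCCCCCCN3CCCC3)ccc12` and compound 3 `O=c1cc(-c2ccccc2O)oc2cc(OCCCCCCCCN3CCCC3)ccc12`. In an ADME assay on HepG2 cells (Homo sapiens) for cytotoxicity, read by MTT assay, with a stated time of 48 h, tested at 1 uM (a higher number here means a stronger effect of the compound at the concentration tested, a lower number a weaker effect), compound 1 gives 19%, compound 2 gives 13.9% and compound 3 gives 5.92%, the lowest of the three numbers. Aryl swaps have so far moved the read-out little: a number 5.1 percentage points lower from compound 1 to compound 2 (within the scatter) and a number 8 percentage points lower from compound 2 to compound 3 (within the scatter), while a number 13.1 percentage points lower from compound 1 to compound 3 (beyond the scatter). Compound 4 `COc1cc(-c2cc(=O)c3ccc(OCCCCCCCCN4CCCC4)cc3o2)cc(OC)c1OC` carries the change (3,4,5-trimethoxyphenyl in place of 2-hydroxyphenyl on an aromatic carbon). Every measured step that bears on it, each a change of the same aryl group, stayed within the scatter or was modest, so no shift beyond the scatter is expected here. The estimate for compound 4 is 10%, range 0% to 24%, an expected step of a number 4.1 percentage points higher from compound 3 to compound 4 (within the scatter).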

Compound 4, a percentage reported as inhibition, at one concentration (the size of the read-out at that concentration, not a potency): 16.3%
Beside the measured number, compound 4's estimate is 6.3 percentage points below it; low and high end bracket the measured number.
By their numbers in this assay, from the lowest: compounds 3, 2, 4 and 1 (each within the scatter of the next, the first and the last beyond it).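

In this assay the 3,4,5-trimethoxyphenyl group gives a step beyond the scatter against the 2-hydroxyphenyl group, with a number 10.4 percentage points higher from compound 3 to compound 4 (beyond the scatter), even though it has no hydrogen-bond donor. Against the other aryl groups it stays within the scatter, with a number 2.4 percentage points higher from compound 2 to compound 4 (within the scatter) and a number 2.7 percentage points lower from compound 1 to compound 4 (within the scatter), so this change does not separate it from either. Nothing at hand explains these steps. Open, going by these compounds, is how an aryl group bearing an amine or a carboxylic acid would behave at this position. A single tested concentration also leaves potency unresolved.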